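This account rests on a few compounds, and the source may have more. Where it says the series, first, only, none or still open, it means among the compounds named here.

Measured so far:
compound 1 `N/C(=N/NC(CC(=O)c1ccc(-n2ccnc2)cc1)c1ccccc1[N+](=O)[O-])c1ccccn1`: 48000 nM
compound 2 `N/C(=N/NC(CC(=O)c1ccc(-n2ccnc2)cc1)c1cccc(F)c1)c1ccccn1`: 26500 nM

Both numbers come from an ADME assay on Vero cells (Chlorocebus sabaeus) for cytotoxicity, read by MTT assay, with a stated time of 72 h; a higher number here means that more compound is tolerated, a lower number that less compound is tolerated. Among the compounds with values here, compound 2 stands at the lower of the two numbers, but the only measured step, a 1.8-fold lower number from compound 1 to compound 2 (0.26 log units; within the scatter), lies within the scatter, so the two compounds cannot be ordered against each other on this assay.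

Compound 3 `N/C(=N/NC(CC(=O)c1ccc(-n2ccnc2)cc1)c1ccccc1F)c1ccccn1` is not yet measured in this assay. It differs from compound 2 in one place only: 2-fluorophenyl in place of 3-fluorophenyl on a saturated chain carbon bound to an amine nitrogen and a saturated chain carbon. Within the data shown here, the one step available bears directly on this place, since it also exchanged the group there, and that step, a 1.8-fold lower number from compound 1 to compound 2 (0.26 log units; within the scatter), gave no movement beyond the scatter. Among the measured compounds shown here, no measured step points in either direction for the present exchange. No step beyond the scatter is therefore expected for compound 3, a 1.1-fold higher number from compound 2 to compound 3 (0.05 log units; within the scatter). Compound 3 is estimated in this assay at 30000 nM, within the range 12000 nM to 75000 nM.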

Compound 3, half-maximal cytotoxic concentration: 62100 nM
For compound 3 the middle estimate is 2.1-fold (0.32 log units) below the measured one; the range from low to high includes it.
By their numbers in this assay, from the lowest: compounds 2, 1 and 3 (each within the scatter of the next, the first and the last beyond it).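

In this assay, within the data shown here, 2-fluorophenyl in place of 3-fluorophenyl on a saturated chain carbon bound to an amine nitrogen and a saturated chain carbon gives the first step at this place beyond the scatter: a 2.3-fold higher number from compound 2 to compound 3 (0.37 log units; beyond the scatter), a modest step between two groups with the same atoms. Fluoro in place of nitro on an aromatic carbon stays within the scatter, a 1.3-fold higher number from compound 1 to compound 3 (0.11 log units; within the scatter), so the two groups on that ring cannot be ordered on this assay. Nothing at hand gives a reason for the modest step.

Compound 1 also carries its group as a 2-substituted phenyl, yet its step from compound 2 stays within the scatter, so no general rule for that arrangement follows. As far as these compounds go, whether 4-fluorophenyl, 2-chlorophenyl or unsubstituted phenyl at this place would stand with compound 2 or compound 3 remains open.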